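A few compounds are considered here, and "the series" means these few. Any claim that something is new, unique, unknown or untested is made for them only; others in the source may bear on it.

Compound 1 `CNc1nc(Cl)nc2c1ncn2C[C@H](COP(=O)(O)O)OP(=O)(O)O` was tested in a functional assay for inhibition, with Rattus norvegicus as the target (a higher number here means a weaker inhibitor, a lower number a stronger inhibitor), where compound 1 gives 2600 nM. Among the two compounds measured, compound 1 has the lowest number; compound 2 `CNc1nc(Cl)nc2c1ncn2CC(COC(C)=O)COC(C)=O` gives 18000 nM in this assay, a gap beyond the usual scatter. Compound 3 `CNc1nc(Cl)nc2c1ncn2C[C@@H](COP(=O)(O)O)OP(=O)(O)O` has not yet been measured. It differs from compound 1 in one way: the two compounds have the same atoms and bonds and differ only in configuration as drawn: 1 of 1 stereo elements differ; a stereocentre at a saturated chain carbon is drawn R in compound 1 and S in compound 3. For the measured compounds named here, no measured pair shows what this change does here, so a moderate step towards a higher number in this assay is expected. The value expected for compound 3 is 5000 nM, with a range from 1500 nM to 25000 nM. The step this estimate means, a 1.9-fold higher number from compound 1 to compound 3 (0.28 log units; within the scatter), is expected rather than known.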

Compound 3, inhibition constant: 1400 nM
Compound 3: middle estimate off by 3.6-fold (0.55 log units), on the high side; measured number below the stated range.
By their numbers in this assay, from the lowest: compounds 3 and 1 (each within the scatter of the next); then compound 2.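

For the compounds shown here, until now, no pair of compounds showed what the configuration at this saturated chain carbon does. Redrawing the stereocentre from R to S gives a 1.9-fold lower number from compound 1 to compound 3 (0.27 log units; within the scatter), so in this assay this change does not separate the two compounds. The comparison isolates this stereocentre: the fact that compounds 1 and 3 differ only in the configuration as drawn.

The compounds shown leave open whether the stereocentre would matter as little with other groups on the chain. A carboxylic acid in place of either phosphate, or a longer chain, could test this.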